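The source may hold more compounds than are shown below. What is called first, only, known or untested is meant among the compounds shown, and "the series" means these compounds.

For the measured compounds named here, in a toxicity assay on J774.A1 cells (Mus musculus) for cytotoxicity, read by SYBR Green assay, with a stated time of 1 h (a higher number here means that more compound is needed for the effect, a lower number that less compound is needed), compound 1 (`CN(C)c1ccc2cc(-c3ccccc3Cl)c(N)nc2c1`) gives 2400 nM as the lower of the two numbers so far, and compound 2 (`CN(C)c1ccc2cc(-c3ccc(Cl)cc3Cl)c(N)nc2c1`) gives 8700 nM as the higher one. Compound 3 (`CN(C)c1ccc2cc(-c3ccccn3)c(N)nc2c1`) carries pyridin-2-yl in place of 2-chlorophenyl on an aromatic carbon of the shared core. Going by the values given here, only one measured step bears on this, and only loosely: a 3.6-fold higher number from compound 1 to compound 2 (0.56 log units; beyond the scatter) for chloro in place of hydrogen on an aromatic carbon. Among the compounds with values here, a similarly modest rise is therefore expected in this assay for this swap, though no measured step makes the same change. The expected change is a 2.1-fold higher number from compound 1 to compound 3 (0.32 log units; beyond the scatter) in this estimate. For compound 3 the expected value is 5000 nM (1800 nM to 14000 nM).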

Compound 3, half-maximal effective concentration: 2200 nM
Compound 3: the middle estimate sits 2.3-fold (0.36 log units) above what was measured, and the stated range covers the measured number.
By their numbers in this assay, from the lowest: compounds 3 and 1 (each within the scatter of the next); then compound 2.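

Replacing 2-chlorophenyl with pyridin-2-yl on the shared core gives a 1.1-fold lower number from compound 1 to compound 3 (0.04 log units; within the scatter) in this assay. At this position, then, a ring with one ring nitrogen and no chlorine can stand in for the chlorinated ring with no change beyond the scatter, so cytotoxicity here does not depend on keeping that chlorine. No measurement at hand explains this result.

Still open, on these data alone, is how plain phenyl, pyridin-3-yl or pyridin-4-yl would compare at this position. Also open, as far as these compounds go, is what an amine or a carboxylic acid on this ring would do.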